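A few compounds are considered here, and "the series" means these few. Any claim that something is new, unique, unknown or untested is made for them only; others in the source may bear on it.

Measured compounds:
Compound 1, `CC(C)CCn1ccc(-c2ccccc2)c(C#N)c1=O`: in a functional assay on CHO cells for positive allosteric modulation of metabotropic glutamate receptor 2 (Homo sapiens), read by scintillation counting and GTPgammaS binding, with a stated time of 30 min (a lower number here means a smaller maximal response, a higher number a larger maximal response), compound 1 gives 117%.
Compound 2, `COc1ccc(-c2ccn(CCC(C)C)c(=O)c2C#N)cc1`: in this assay compound 2 gives 160%.
Compound 3, `CC(C)CCn1ccc(-c2ccc(Oc3ccccc3)cc2)c(C#N)c1=O`: in this assay compound 3 gives 188%.

Compound 3 stands highest of the three numbers; compound 2 is nearest to it and compound 1 furthest, and both gaps lie beyond the scatter. The measured steps are a number 43 percentage points higher from compound 1 to compound 2 (beyond the scatter), a number 71 percentage points higher from compound 1 to compound 3 (beyond the scatter) and a number 28 percentage points higher from compound 2 to compound 3 (beyond the scatter).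

Compound 4, `CC(C)CCn1ccc(-c2ccc(Oc3ccccn3)cc2)c(C#N)c1=O`, differs from compound 3 in one place: pyridin-2-yl in place of phenyl on an oxygen on an aromatic ring. Going by the values given here, no measured step exchanges one aromatic ring for another on that oxygen. Among the compounds with values here, the only step touching the oxygen is a number 28 percentage points higher from compound 2 to compound 3 (beyond the scatter), which was modest, so the data give no ground for a large movement in either direction when the ring on the oxygen is kept but one of its carbons becomes a nitrogen. Compound 4 is therefore expected to give about 175%, in the range 140% to 205%, which means an expected step of a number 13 percentage points lower from compound 3 to compound 4 (beyond the scatter), within the scatter.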

Compound 4, largest response reached (Emax), in percent of the reference or control that the assay uses: 249%
The estimate for compound 4 lay 74 percentage points below the measured number; measured number outside the range, above it.
By their numbers in this assay, from the lowest: compound 1; then compound 2; then compound 3; then compound 4.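

In this assay the ring on the oxygen proved to be far from interchangeable: pyridin-2-yl in place of phenyl gives a number 61 percentage points higher from compound 3 to compound 4 (beyond the scatter) and so extends the response beyond what the phenoxy group had reached. The earlier compounds shown here showed only that larger replacements on the aromatic carbon raised the number, whereas this change keeps the ring and its heavy-atom count and exchanges one carbon for a nitrogen; the wider steps, a number 89 percentage points higher from compound 2 to compound 4 (beyond the scatter) and a number 132 percentage points higher from compound 1 to compound 4 (beyond the scatter), show how much is gained at this position overall. Nothing available accounts for the gain.

As far as these compounds go, it remains open whether the placing of the nitrogen matters, as pyridin-3-yl or pyridin-4-yl on the same oxygen would show. From the compounds shown here alone, it is also open whether a second ring nitrogen, as in pyrimidin-2-yl, would carry the response further.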